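Sulfonyl carbon substituents in a WNK1 inhibitor series

A few compounds are considered here, and "the series" means these few. Any claim that something is new, unique, unknown or untested is made for them only; others in the source may bear on it.

Compound 1 `O=[N+]([O-])c1cc(S(=O)(=O)C(Cl)(Cl)Br)ccc1NC1CCCCC1`: 4000 nM
Compound 2 `CCS(=O)(=O)c1ccc(NC2CCCCC2)c([N+](=O)[O-])c1`: > 1000000 nM (a limit)
Compound 3 `O=[N+]([O-])c1cc(S(=O)(=O)C(F)(F)F)ccc1NC1CCCCC1`: > 1000000 nM (a limit)

In an assay on cells for inhibition of serine/threonine-protein kinase WNK1 (Homo sapiens), read by luminescence and Kinase-Glo, with a stated time of 2 h (a lower number here means a stronger inhibitor, a higher number a weaker inhibitor), compound 1 gives 4000 nM. Compound 2 yields only the limit > 1000000 nM. Compound 3 likewise yields only the limit > 1000000 nM, so it stands at the weak end of what is shown, at the limit of > 1000000 nM in this assay, at which 2 of the 3 values shown sit.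

Compound 4 `O=[N+]([O-])c1cc(S(=O)(=O)C(Cl)Cl)ccc1NC1CCCCC1` differs from compound 3 by dichloromethyl in place of trifluoromethyl on a sulfonyl sulfur. The step that bears on this is an at least 250-fold higher number from compound 1 to compound 3 (2.39 log units; beyond the scatter), which shows the trifluoromethyl far weaker than bromo(dichloro)methyl; an at least 250-fold higher number from compound 1 to compound 2 (2.39 log units; beyond the scatter) shows the same for ethyl. Dichloromethyl keeps two chlorines of the group in compound 1 but lacks its bromine, so a fall in the number toward compound 1 is expected, of uncertain depth. Compound 4 is therefore estimated at 50000 nM, within 4000 nM to 1000000 nM, the expected step being an at least 20-fold lower number from compound 3 to compound 4 (1.30 log units; beyond the scatter).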

Compound 4, half-maximal inhibitory concentration: > 1000000 nM
Compound 4: no number, only a limit; the forecaster's own chance of this, stated with the estimate: 35%; at least 20-fold (1.30 log units) between middle value and limit.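

Hydrogen in place of bromo on the saturated chain carbon gives an at least 250-fold higher number from compound 1 to compound 4 (2.39 log units; beyond the scatter). Compound 4 yields only a limit: the limit of > 1000000 nM in this assay, at which 3 of the 4 values shown sit. The two chlorines alone therefore do not restore a measured number in this assay, and the steps from compound 2 and compound 3 to compound 4 cannot be read, as both ends are limits.

On these data alone, the order among ethyl, trifluoromethyl and dichloromethyl stays open. Also open, as far as these compounds go, is how trichloromethyl or bromomethyl on the sulfonyl sulfur would read, and so whether bromine itself is required.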